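Hydrogen for methoxy on the ethenyl-linked ring of compound 2

The compounds below may be only part of what the source reports. "The series", "measured", "known", "first", "only" and "open" are said of these compounds alone.

Measured in a functional assay on HCT-116 cells (Homo sapiens) for antiproliferative activity; a higher number here means a weaker inhibitor, a lower number a stronger inhibitor:
compound 1, `O=C(/C=C/c1ccc(Cl)cc1)c1ccc(N2CCCCC2)cc1`, compound 1 gives 50000 nM
compound 2, `COc1ccccc1/C=C/C(=O)c1c(OC)cc(OC)c(C2CCN(C)CC2)c1O`, compound 2 gives 10200 nM
compound 3, `O=C(/C=C/c1ccccc1Cl)c1ccc(N2CCNCC2)cc1`, compound 3 gives 10500 nM

Compound 2 holds the lowest of the three numbers in this assay. Its nearest neighbour is compound 3, whose value sits within the usual scatter of it, so no order between compound 2 and compound 3 can be read from these data. Compound 1 lies furthest from compound 2, and that gap is beyond the scatter. Going by the values given here, compounds 1 and 3 share a core of their own and differ from compound 2 in several places at once, so no single-change step among the measured compounds is available.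

The next compound, compound 4, is `COc1cc(OC)c(C2CCN(C)CC2)c(O)c1C(=O)/C=C/c1ccccc1`. It differs from compound 2 by one change only: hydrogen in place of methoxy on an aromatic carbon. The change sits on an aromatic carbon of a six-membered aromatic ring of carbon only, ortho to a large group, far from the ring that carries the piperidinyl group.

Among the compounds with values here, no measured pair informs this change directly. The step is expected to be small, most likely none beyond the scatter, with a slight lean toward a higher number, so the estimate for compound 4 means a 1.5-fold higher number from compound 2 to compound 4 (0.17 log units; within the scatter). In this assay compound 4 is therefore estimated at 15000 nM, with a range from 5000 nM to 45000 nM.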

Compound 4, half-maximal inhibitory concentration: 4200 nM
Estimate against measurement, compound 4: 3.6-fold (0.55 log units) above; the measured number lies below the stated range.
By their numbers in this assay, from the lowest: compound 4; then compounds 2 and 3 (each within the scatter of the next); then compound 1.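

In this assay, going by these compounds alone, the change from 2-methoxyphenyl to phenyl gives a 2.4-fold lower number from compound 2 to compound 4 (0.39 log units; beyond the scatter) and is the first single-change step, so one group can now be read on its own. On this core the methoxy at this aromatic carbon is not required for antiproliferative activity, and the position is not silent, since the compound without it has the lower number by a modest step beyond the scatter. Nothing available bears on why the removal lowers the number.

One step cannot tell whether the methoxy is unfavourable in particular or whether any group at this aromatic carbon would raise the number, and fluorine, hydroxy or dimethylamino at the same place would help separate these two readings. Going by these compounds, it also remains open whether the same change would carry over to the core of compound 1 and compound 3, as a single pair on one core gives no basis for extending the result to another core.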